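A few compounds are considered here, and "the series" means these few. Any claim that something is new, unique, unknown or untested is made for them only; others in the source may bear on it.

Measured so far:
compound 1, `COc1ccc(-c2nn(-c3ccccc3)c(-c3ccc(C)cc3)c2S(=O)(=O)CC2=NCCO2)cc1`, 67.6% in a functional assay, tested at 50 ug/mL; on this read-out higher numbers stand for a stronger effect at the one concentration tested and lower numbers for a weaker effect;
compound 2, `O=S(=O)(CC1=NCCS1)c1c(-c2ccccc2)noc1-c1ccccc1`, "not active" (no number reported) in this assay.

Compound 2 stands with no number in this assay, reported only as not active. Compound 3, `O=S(=O)(CC1=NCCO1)c1c(-c2ccccc2)noc1-c1ccccc1`, differs from compound 2 by a group of 5 heavy atoms (3 carbon, 1 nitrogen, 1 oxygen; one five-membered non-aromatic ring with 2 hetero atoms) in place of a group of 5 heavy atoms (3 carbon, 1 nitrogen, 1 sulfur; one five-membered non-aromatic ring with 2 hetero atoms), on a saturated chain carbon bound to a sulfonyl sulfur. For the measured compounds named here, compound 1, which carries the entering group on a different core, gives 67.6% in this assay, but no single-change step connects it to compound 2 or compound 3. Going by the values given here, since compound 2 is inactive and no measured step covers this change, only a small effect, if any beyond the scatter, is expected for compound 3 in this assay. Compound 3 is estimated at 20%, range 0% to 55%.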

Compound 3, a percentage reported as activity, at one concentration (the size of the read-out at that concentration, not a potency): 57.2%
Compound 3: middle estimate off by 37.2 percentage points, on the low side, and the stated range ends below it.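

For the compounds shown here, compound 2 is reported without a number in this assay, and no step to compound 3 can be read from it. The compounds shown leave open the size of the effect of exchanging the sulfur-containing ring for the oxygen-containing ring, and no data at hand bear on the result.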